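The source may hold more compounds than are shown below. What is called first, only, known or untested is meant among the compounds shown, and "the series" means these compounds.

Working notes on the series. In a functional assay on KB cells (Homo sapiens) for inhibition, read by sulforhodamine B assay (a lower number here means a stronger inhibitor of growth, a higher number a weaker inhibitor of growth), compound 3 `Cc1ccc2[nH]c(-c3ccc(-c4ccc(-c5ccccc5)cc4)cc3)nc2c1` gives 32100 nM. This lies within the scatter of compound 2 `Fc1ccc(-c2ccc(-c3ccc(-c4nc5ccccc5[nH]4)cc3)cc2)cc1` at 41300 nM and well apart from compound 1 `COc1ccc(-c2ccc(-c3ccc(-c4nc5cc(C)ccc5[nH]4)cc3)cc2)cc1OC` at 2190 nM.

The next analogue is compound 4 `Cc1ccc2[nH]c(-c3ccc(-c4ccc(-c5ccc(F)cc5)cc4)cc3)nc2c1`, with the change fluoro in place of hydrogen on an aromatic carbon, para to a large group.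

Among the measured compounds shown here, the only measured step at this ring is a 15-fold higher number from compound 1 to compound 3 (1.17 log units; beyond the scatter), a large step for phenyl in place of 3,4-dimethoxyphenyl. For the measured compounds named here, it involves a different substituent, so it gives no direct size for the present change, and no measured step isolates fluoro. The closest evidence is compound 2, which carries the same 4-fluorophenyl group on a different core and gives 41300 nM. On that value, no step beyond the scatter is expected in this assay.

For compound 4 the estimated value is 33000 nM, with an expected range of 14000 nM to 75000 nM. The expected change is a 1.0-fold higher number from compound 3 to compound 4 (0.01 log units; within the scatter).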

Compound 4, concentration for 50% growth inhibition: 24900 nM
Beside the measured number, compound 4's estimate is 1.3-fold (0.12 log units) above it; the measured number falls inside the stated range.
By their numbers in this assay, from the lowest: compound 1; then compounds 4, 3 and 2 (each within the scatter of the next).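

In this assay, among the compounds shown here, fluoro in place of hydrogen, para to a large group, gives a 1.3-fold lower number from compound 3 to compound 4 (0.11 log units; within the scatter), the first direct reading of this change, and it stays within the scatter. With the 4-fluorophenyl group held constant, adding a methyl group to the core gives a 1.7-fold lower number from compound 2 to compound 4 (0.22 log units; within the scatter), so this second change also stays within the scatter. The replacement of 3,4-dimethoxyphenyl by 4-fluorophenyl gives an 11-fold higher number from compound 1 to compound 4 (1.06 log units; beyond the scatter), so compound 1 stands well apart from compound 4, as it does from compound 3 through a 15-fold higher number from compound 1 to compound 3 (1.17 log units; beyond the scatter).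

No evidence is available to explain these steps. From the compounds shown here alone, whether a single methoxy group, a hydroxyl group or an amine on this ring would retain the lower number of compound 1 remains open.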